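A few compounds are considered here, and "the series" means these few. Any claim that something is new, unique, unknown or untested is made for them only; others in the source may bear on it.

Compound 1 `c1ccc(-c2ccc3cccnc3n2)cc1` gives 1840 nM in a functional assay on CHO cells for antagonist activity at metabotropic glutamate receptor 5 (Rattus norvegicus), read by calcium flux; a higher number here means a weaker inhibitor, a lower number a stronger inhibitor. Compound 2 `Cc1cccc(-c2ccc3cccnc3n2)c1` carries methyl in place of hydrogen on an aromatic carbon and gives 225 nM in this assay, a step of an 8.2-fold lower number from compound 1 to compound 2 (0.91 log units; beyond the scatter). Compound 3 `Cc1ccc2cnc(-c3ccccc3)cc2n1` is built on a different core from compound 1; the difference between the two cores is not broken down here. In this assay compound 3 reaches only a limit, > 30000 nM. Compound 4 `Cc1cccc(-c2cc3nc(C)ccc3cn2)c1` is not yet measured; it differs from compound 3 by methyl in place of hydrogen on an aromatic carbon, the same change as that between compound 1 and compound 2, at the same place. For compound 4 the expected step is an at least 2.0-fold lower number from compound 3 to compound 4 (0.30 log units; that floor lies within the scatter), resting only on the measured step of an 8.2-fold lower number from compound 1 to compound 2 (0.91 log units; beyond the scatter), since the starting point of compound 3 sits at the limit of > 30000 nM in this assay, at which 1 of the 3 values shown sits, and a step of the earlier size from there would still leave a weak inhibitor. Compound 4 is therefore expected near 15000 nM in this assay, between 3000 nM and 60000 nM, with a real chance that only a limit is again reported.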

Compound 4, half-maximal inhibitory concentration: 676 nM
For compound 4 the middle estimate is 22-fold (1.35 log units) above the measured one; measured number outside the range, below it.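

In this assay, methyl in place of hydrogen on an aromatic carbon of the six-membered ring of carbon only, meta to a large group, gives an at least 44-fold lower number from compound 3 to compound 4 (1.64 log units; beyond the scatter), so the number falls on this core as it did on the core of compound 1. The direction of the change carries from one core to the other, but its size does not, and nothing here explains the gap between the two steps: the same change on two cores in this assay, an 8.2-fold lower number (0.91 log units; beyond the scatter) from compound 1 to compound 2 and an at least 44-fold lower number (1.64 log units; beyond the scatter) from compound 3 to compound 4, at least 5.4-fold (0.73 log units) apart, beyond the scatter of two such steps
The larger step is only a floor and its full size remains unknown, as compound 3 sits at a limit: the limit of > 30000 nM in this assay, at which 1 of the 4 values shown sits.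

The compounds shown leave open whether the drop in the number belongs to methyl alone or would also come with ethyl, chlorine or methoxy in the same place. From the compounds shown here alone, two cores also fix no general rule, so it remains open how far the change would carry on to any further core.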